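Arylmethylamine swap on a bis(trifluoromethyl)benzenesulfonamide series

This account rests on a few compounds, and the source may have more. Where it says the series, first, only, none or still open, it means among the compounds named here.

Measured so far:
compound 1 `O=S(=O)(NCCNCc1ccc(-c2ccccc2)cc1)c1cc(C(F)(F)F)cc(C(F)(F)F)c1` gives 1400 nM in a functional assay on MCF7 cells (Homo sapiens) for inhibition, read by MTT assay, with a stated time of 72 h; on this read-out lower numbers stand for stronger inhibition of growth and higher numbers for weaker inhibition of growth
compound 2 `O=S(=O)(NCCCNCc1ccc(Cl)c(Cl)c1)c1cc(C(F)(F)F)cc(C(F)(F)F)c1` gives 2400 nM in this assay
compound 3 `COc1ccc(CNCCCNS(=O)(=O)c2cc(C(F)(F)F)cc(C(F)(F)F)c2)cc1OC` gives 1900 nM in this assay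

Compound 3 sits second highest of the three numbers; its gap to compound 2 and its gap to compound 1 both lie within the scatter, so no order among the three can be read. Going by the values given here, the one single-point step available, a 1.3-fold lower number from compound 2 to compound 3 (0.10 log units; within the scatter), is an exchange of the aryl group on the saturated chain carbon bound to the amine nitrogen and left the number essentially unchanged.

Compound 4 `O=S(=O)(NCCCNCc1cccc2ccccc12)c1cc(C(F)(F)F)cc(C(F)(F)F)c1` is the next member, not yet measured. Its difference from compound 3 is naphthalen-1-yl in place of 3,4-dimethoxyphenyl on a saturated chain carbon bound to an amine nitrogen. This is the same kind of change as the step from compound 2 to compound 3: a swap of the aryl group at the same place, with the chain and the sulfonamide core untouched. Compound 1 carries a larger aryl group on a shorter chain and its value is close to that of compound 3, but the two differ in more than one place, so only the two values themselves can be compared. On this basis, the step of a 1.2-fold lower number from compound 3 to compound 4 (0.07 log units; within the scatter) is expected to stay within the scatter.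

Compound 4 is therefore estimated at 1600 nM in this assay, with a range of 600 nM to 4500 nM.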

Compound 4, concentration for 50% growth inhibition: 1400 nM
Compound 4: middle estimate off by 1.1-fold (0.06 log units), on the high side; the range from low to high includes it.
By their numbers in this assay, from the lowest: compounds 1, 4, 3 and 2 (each within the scatter of the next).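

At the place on a saturated chain carbon bound to an amine nitrogen, the series now holds a naphthalen-1-yl group as well as two single-ring aryl groups. In this assay, the exchange for 3,4-dimethoxyphenyl gives a 1.4-fold lower number from compound 3 to compound 4 (0.13 log units; within the scatter) and the exchange for 3,4-dichlorophenyl gives a 1.7-fold lower number from compound 2 to compound 4 (0.23 log units; within the scatter), so neither step separates the groups. A second six-membered aromatic ring and the absence of the two hydrogen-bond acceptors of 3,4-dimethoxyphenyl, at an equal heavy-atom count, thus leave the number within the scatter; no measured property bears on this result.

As far as these compounds go, whether a pyridine ring or an aryl group carrying a carboxylic acid at this place would give a step beyond the scatter remains open. From the compounds shown here alone, the effect of a longer chain also remains open, since compound 1 and compound 4 differ in more than one place.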